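The source may hold more compounds than are shown below. What is called first, only, known or untested is meant among the compounds shown, and "the series" means these compounds.

In an ADME assay on HepG2 cells (Homo sapiens) for cytotoxicity, read by luminescence, with a stated time of 72 h (a higher number here means that more compound is needed for the effect, a lower number that less compound is needed), the measured compounds are:

- Compound 1 `CCOC(=O)c1c(-c2cccc(-c3ccccc3)c2)[nH]c2cc(OC)ccc2c1=O`: > 21500 nM
- Compound 2 `CCOC(=O)c1c(-c2cccc(S(C)(=O)=O)c2)[nH]c2cc(OC)ccc2c1=O`: > 21500 nM
- Compound 3 `CCOC(=O)c1c(-c2cccc(O)c2)[nH]c2cc(OC)ccc2c1=O`: > 21500 nM

Each entry is a limit and not a number, so compound 1 offers no exact starting value. All three compounds share one ceiling: the limit of > 21500 nM in this assay, at which 3 of the 3 values shown sit.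

Compound 4 `CCOC(=O)c1c(-c2cccc(-c3ccccc3)c2)[nH]c2cc(OC)c(Cl)cc2c1=O` differs from compound 1 at one place: chloro in place of hydrogen on an aromatic carbon. This is chloro in place of hydrogen on an aromatic carbon, ortho to a methoxy group.

Three measured steps are available: a step that the two limits leave unreadable from compound 1 to compound 2, a step that the two limits leave unreadable from compound 1 to compound 3 and a step that the two limits leave unreadable from compound 2 to compound 3. The first swaps phenyl for methylsulfonyl, the second swaps phenyl for hydroxy, and the third swaps methylsulfonyl for hydroxy. None of them adds chloro, and none has a readable size, so they bear on this change only loosely. Within the data shown here, they show only that these three compounds share the same limit despite those swaps.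

On that thin basis, no step beyond the usual scatter is expected in this assay, and the estimated step is a step that the limit leaves unreadable from compound 1 to compound 4. A reported limit is the most likely outcome, with a true number possible but less likely. For compound 4 the estimated value is 25000 nM, with an expected range from 10000 nM to 60000 nM.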

Compound 4, half-maximal effective concentration: > 21500 nM
Compound 4: a limit, no number; the forecaster's own chance of this, stated with the estimate: 85%; the middle value does not contradict the limit.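

In this assay compound 4 gives > 21500 nM, which is a limit and not a number. Compound 1 also stands at a limit, so no step can be read for chloro in place of hydrogen between compound 1 and compound 4, because the values share one ceiling: the limit of > 21500 nM in this assay, at which 4 of the 4 values shown sit.

The compounds shown leave open whether chloro changes the true half-maximal effective concentration at all.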